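Thiophen-2-yl in place of 4-chlorophenyl

The source may hold more compounds than are shown below. What is called first, only, known or untested is meant among the compounds shown, and "the series" means these compounds.

Within the data shown here, in a functional assay on MDA-MB-435 cells (Homo sapiens) for cytotoxicity, read by MTT assay, with a stated time of 72 h (a higher number here means a weaker inhibitor, a lower number a stronger inhibitor), compound 1 (`CN(C)c1ccc(CNC(=O)c2nc(Br)c3cccnc3c2N[C@H]2CC[C@H](N)CC2)cc1`) gives 4000 nM, while compound 2 (`N[C@H]1CC[C@H](Nc2c(C(=O)NCc3ccc(Cl)cc3)nc(Br)c3cccnc23)CC1`) gives 1000 nM, the lowest of the two numbers so far. Among the measured compounds shown here, the one measured step, with chloro in place of dimethylamino on an aromatic carbon, is modest but beyond the scatter: a 4.0-fold lower number from compound 1 to compound 2 (0.60 log units; beyond the scatter). Compound 3 (`N[C@H]1CC[C@H](Nc2c(C(=O)NCc3cccs3)nc(Br)c3cccnc23)CC1`) carries thiophen-2-yl in place of 4-chlorophenyl on a saturated chain carbon bound to an amide-type nitrogen. For the measured compounds named here, this change removes the chloro group of compound 2, so the measured step of a 4.0-fold lower number from compound 1 to compound 2 (0.60 log units; beyond the scatter) is the only guide to its size, and a partial one. A small rise in the number is expected, possibly within the scatter, and the estimated step is a 1.8-fold higher number from compound 2 to compound 3 (0.26 log units; within the scatter). Compound 3 is expected to give about 1800 nM, with an estimated range of 700 nM to 5000 nM.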

Compound 3, half-maximal inhibitory concentration: 4100 nM
For compound 3 the middle estimate is 2.3-fold (0.36 log units) below the measured one, and the stated range covers the measured number.
By their numbers in this assay, from the lowest: compound 2; then compounds 1 and 3 (each within the scatter of the next).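

With a 4.1-fold higher number from compound 2 to compound 3 (0.61 log units; beyond the scatter) in this assay, the result shows that a second, quite different replacement for 4-chlorophenyl on this saturated chain carbon also ends well away from compound 2. With a 1.0-fold higher number from compound 1 to compound 3 (0.01 log units; within the scatter), thiophen-2-yl and 4-(dimethylamino)phenyl cannot be told apart here, which leaves compound 2 as the strongest of the three and the only one that stands apart. Nothing measured here accounts for the standing of the 4-chlorophenyl group.

On these data alone, what a plain phenyl, a 4-fluorophenyl or a 4-methoxyphenyl group would give at this place remains open, so the part played by the chloro atom, as distinct from the ring that carries it, is unsettled. Also open, as far as these compounds go, is whether a chlorothiophene, a pyridine ring or a longer chain to the ring would follow compound 2 or compound 3.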